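The compounds below may be only part of what the source reports. "The series", "measured", "known", "first", "only" and "open" are said of these compounds alone.

The series shares one core, seen in compound 1 `CCCCCn1c(N)nc2ccccc21`, which in an assay on HEK293 cells for agonist activity at Toll-like receptor 8 (Homo sapiens), read by reporter gene assay (on this read-out lower numbers stand for an effect already at smaller amounts and higher numbers for an effect only at larger amounts of compound), gives 3230 nM. Compound 2 `CCCCCn1c(N)nc2c(C)cccc21` gives 1130 nM, and the step of a 2.9-fold lower number from compound 1 to compound 2 (0.46 log units; beyond the scatter). Compound 3 `CCCCCn1c(N)nc2c(N(C)C)cccc21` gives 7120 nM, the highest of the three numbers: a 2.2-fold higher number from compound 1 to compound 3 (0.34 log units; beyond the scatter) and a 6.3-fold higher number from compound 2 to compound 3 (0.80 log units; beyond the scatter). Compound 3 thus stands at the top of the set, nearest to compound 1 and furthest from compound 2.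

Compound 4 `CCCCCn1c(N)nc2c(O)cccc21` carries hydroxy in place of dimethylamino on an aromatic carbon. Among the compounds with values here, no measured step involves a hydroxy group, so the expectation rests on the two steps leading into compound 3: a 2.2-fold higher number from compound 1 to compound 3 (0.34 log units; beyond the scatter) shows that dimethylamino in place of hydrogen raised the number, and a 6.3-fold higher number from compound 2 to compound 3 (0.80 log units; beyond the scatter) shows that dimethylamino in place of methyl raised it further. Both point the same way: neither hydrogen nor methyl at this carbon gave a number as high as dimethylamino did, and removing the dimethylamino group again is expected to bring the number back down. A hydroxy group is expected to behave more like those two substituents than like dimethylamino, so compound 4 is expected to move back towards compound 1, with a 2.8-fold lower number from compound 3 to compound 4 (0.45 log units; beyond the scatter) as the estimated step. For compound 4 the estimate in this assay is 2500 nM, with a range from 1000 nM to 6500 nM.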

Compound 4, half-maximal effective concentration: 5010 nM
Compound 4: middle estimate off by 2.0-fold (0.30 log units), on the low side; low and high end bracket the measured number.
By their numbers in this assay, from the lowest: compound 2; then compounds 1, 4 and 3 (each within the scatter of the next, the first and the last beyond it).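

Hydroxy does not separate from dimethylamino on this aromatic carbon, with a 1.4-fold lower number from compound 3 to compound 4 (0.15 log units; within the scatter), and it does not separate from hydrogen either, with a 1.6-fold higher number from compound 1 to compound 4 (0.19 log units; within the scatter), so in this assay compound 4 cannot be ranked against compound 1 or compound 3, although those two remain apart. Methyl, by contrast, remains distinct from hydroxy, with a 4.4-fold higher number from compound 2 to compound 4 (0.65 log units; beyond the scatter), and compound 2 now has the lowest number of the set, with its steps to all three other compounds printed as beyond the scatter; among the four groups compared at this carbon, only methyl gives a clear gain over hydrogen, and compound 3 and compound 4 go against any wider reading of that gain. Nothing available on these compounds accounts for the separate position of methyl or for the closeness of hydroxy to both hydrogen and dimethylamino.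

Going by these compounds, whether the lower number of compound 2 is specific to methyl remains open, since ethyl, methoxy, chlorine or an unsubstituted amine on the same carbon could fall on either side. On these data alone, it is also open whether the methyl step holds when the pentyl chain gives way to a shorter or longer chain.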